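Fluoro on the fused ring of a weak antiproliferative series

A few compounds are considered here, and "the series" means these few. Any claim that something is new, unique, unknown or untested is made for them only; others in the source may bear on it.

Compound 1 `c1ccc(-c2noc(-c3cc4ccccc4[nH]3)n2)cc1` is the parent of this small set; in a functional assay on COLO 320 cells (Homo sapiens) for antiproliferative activity, read by WST assay, with a stated time of 72 h (a lower number here means a stronger inhibitor, a higher number a weaker inhibitor), compound 1 gives 12000 nM. Compound 3 `COc1ccc(-c2noc(-c3cc4ccccc4[nH]3)n2)cc1` carries a methoxy in place of hydrogen on an aromatic carbon, and in this assay compound 3 gives 27700 nM, the highest of the two plain numbers recorded. For the measured compounds named here, the one measured step is a 2.3-fold higher number from compound 1 to compound 3 (0.36 log units; beyond the scatter). Going by the values given here, compound 2 `Fc1ccc2[nH]c(-c3nc(-c4ccc(Cl)cc4)no3)cc2c1` reaches only a limit of the assay, (the limit of > 50000 nM in this assay, at which 1 of the 3 values shown sits), so in this assay compound 2 gives > 50000 nM and no number; compound 2 and compound 1 differ in two places, so no single step is drawn between them.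

Compound 4 `COc1ccc(-c2noc(-c3cc4cc(F)ccc4[nH]3)n2)cc1` is compound 3 with the change (fluoro in place of hydrogen on an aromatic carbon). Among the compounds with values here, no measured step touches this position directly; the only fluoro on the fused system sits in compound 2, which reached the limit. A step toward weaker inhibition, or none beyond the scatter, is therefore expected in this assay for compound 4, with a real chance of a limit. The estimated step is a 1.6-fold higher number from compound 3 to compound 4 (0.21 log units; within the scatter), and compound 4 is expected at 45000 nM, between 18000 nM and 120000 nM.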

Compound 4, half-maximal inhibitory concentration: 14800 nM
Estimate against measurement, compound 4: 3.0-fold (0.48 log units) above; the whole stated range lies above it.
By their numbers in this assay, from the lowest: compounds 1, 4 and 3 (each within the scatter of the next, the first and the last beyond it). At a limit, above all of these: compound 2.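

In this assay, fluoro in place of hydrogen on an aromatic carbon of the fused system of two rings gives a 1.9-fold lower number from compound 3 to compound 4 (0.27 log units; within the scatter), so this position accepts fluoro with no change that can be told from the scatter. Fluoro alone therefore does not go with the limit seen for compound 2: with fluoro kept, methoxy in place of chloro on an aromatic carbon gives an at least 3.3-fold lower number from compound 2 to compound 4 (0.52 log units; beyond the scatter). Compound 2 gives a limit and not a number: the limit of > 50000 nM in this assay, at which 1 of the 4 values shown sits.

Open, as far as these compounds go, is whether chloro without fluoro on the core of compound 1 also reaches the limit, and whether fluoro reads the same with hydrogen in place of methoxy. Also open, from the compounds shown here alone, is how an amine or a carboxylic acid at this position on the fused system would read in this assay.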